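A few compounds are considered here, and "the series" means these few. Any claim that something is new, unique, unknown or untested is made for them only; others in the source may bear on it.

The measured compounds:

Compound 1, `Nc1ccccc1NC(=O)c1ccc(CSC(=S)N2CCc3ccccc32)cc1`: 87%
Compound 2, `Nc1ccccc1NC(=O)c1ccc(CSC(=S)N2CCc3cc(Cl)ccc32)cc1`: 82.2%

In a functional assay on MGC-803 cells (Homo sapiens) for antiproliferative activity, read by CCK-8 assay, with a stated time of 72 h, tested at 8 uM (a higher number here means a stronger effect of the compound at the concentration tested, a lower number a weaker effect), compound 1 gives 87%, and compound 2 gives 82.2%. Going by the values given here, the single measured step, a number 4.8 percentage points lower from compound 1 to compound 2 (within the scatter), lies within the scatter, so the two numbers cannot be told apart with confidence. Compound 2 therefore stands at one of two numbers that sit within the scatter of each other, the nearest being that of compound 1.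

Compound 3, `Nc1ccccc1NC(=O)c1ccc(CSC(=S)N2CCc3cc([N+](=O)[O-])ccc32)cc1`, has not yet been measured. It differs from compound 2 as follows: nitro in place of chloro on an aromatic carbon. Among the compounds with values here, the only measured step that bears on this change is the one from compound 1 to compound 2, which concerns the same aromatic carbon and was within the scatter. Within the data shown here, no step exists for the exchange of chloro against nitro anywhere in this set. On this basis compound 3 is expected to give a number close to that of compound 2, with a number 0.2 percentage points lower from compound 2 to compound 3 (within the scatter) expected to stay within the scatter. The estimate for compound 3 in this assay is 82%, with a range from 68% to 92%.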

Compound 3, a percentage reported as inhibition, at one concentration (the size of the read-out at that concentration, not a potency): 33.2%
Compound 3: the middle estimate sits 48.8 percentage points above what was measured, and the stated range ends above it.
By their numbers in this assay, from the lowest: compound 3; then compounds 2 and 1 (each within the scatter of the next).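

Nitro in place of chloro gives a number 49 percentage points lower from compound 2 to compound 3 (beyond the scatter) and nitro in place of hydrogen gives a number 53.8 percentage points lower from compound 1 to compound 3 (beyond the scatter) in this assay, so this aromatic carbon, where chloro and hydrogen could not be told apart, does not treat every group alike. The tolerance seen with chloro therefore belongs to that group and cannot be carried over to all groups at this place, para to a fused ring and meta to a fused ring. Nitro brings three heavy atoms where chloro has one, and two hydrogen-bond acceptors where chloro has none, but nothing available here connects either difference to the lower number or gives a reason for it.

With only hydrogen, chloro and nitro shown at this carbon, it remains open whether a nitrile, which also carries no hydrogen-bond donor, would fall with nitro or stay with chloro, and where a methoxy group or an amine would land. As far as these compounds go, it is also open whether nitro would cost as much on another carbon of the same aromatic ring.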